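Swapping a benzyl for a phenyl on the sulfonyl sulfur

This account rests on a few compounds, and the source may have more. Where it says the series, first, only, none or still open, it means among the compounds named here.

Of the compounds shown here, three sharing one core have been tested in a functional assay on DU-145 cells (Homo sapiens) for inhibition, read by trypan blue exclusion, with a stated time of 96 h; on this read-out lower numbers stand for stronger inhibition of growth and higher numbers for weaker inhibition of growth. Compound 1 `Cc1cc(C)cc(/C=C(\C(=O)c2ccc(Cl)cc2)S(=O)(=O)c2ccc(Br)cc2)c1` gives 10000 nM. Compound 2 `COc1ccccc1/C=C(\C(=O)c1ccc(Cl)cc1)S(=O)(=O)c1ccc(C)cc1` gives 1000 nM. Compound 3 `Cc1ccc(CS(=O)(=O)/C(=C/c2cc(C)cc(C)c2)C(=O)c2ccc(Cl)cc2)cc1` gives 10000 nM, which is level with compound 1 at the digits shown; together they hold the highest numbers of the three, while compound 2 sits no change at the digits printed from compound 1 to compound 3 (within the scatter) aside as the only one with a clearly lower number.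

The next compound, compound 4 `Cc1ccc(S(=O)(=O)/C(=C/c2cc(C)cc(C)c2)C(=O)c2ccc(Cl)cc2)cc1`, keeps everything in compound 3 except one group on the sulfonyl sulfur: 4-methylphenyl in place of 4-methylbenzyl on a sulfonyl sulfur.

Within the data shown here, only one measured step touches this position. From compound 1 to compound 3 a 4-methylbenzyl replaced a 4-bromophenyl on the same sulfonyl sulfur, and the outcome was no change at the digits printed from compound 1 to compound 3 (within the scatter). That step suggests that changes at this group, at least between these aryl and benzyl forms, leave the growth-inhibiting concentration roughly where it was. Compound 2 also carries a 4-methylphenyl on its sulfonyl sulfur, but it differs from compound 4 elsewhere too, so its lower number cannot be read as a guide here.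

The expected step in this assay is therefore no change at the digits printed from compound 3 to compound 4 (within the scatter), that is, nothing beyond the scatter. Compound 4 is estimated at 10000 nM, with a likely range from 3000 nM to 30000 nM.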

Compound 4, concentration for 50% growth inhibition: 1000 nM
The estimate for compound 4 lay 10-fold (1.00 log units) above the measured number; measured number outside the range, below it.
By their numbers in this assay, from the lowest: compounds 2 and 4 (each within the scatter of the next); then compounds 1 and 3 (each within the scatter of the next).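

In this assay, 4-methylphenyl in place of 4-methylbenzyl on the sulfonyl sulfur brings a 10-fold lower number from compound 3 to compound 4 (1.00 log units; beyond the scatter) and so shows that this position can respond, which the earlier flat step between an aryl and a benzyl group did not reveal. Methyl in place of bromo on an aromatic carbon gives a 10-fold lower number from compound 1 to compound 4 (1.00 log units; beyond the scatter) and shows that a change on the 4-substituted phenyl group itself also counts, so the level numbers of compound 1 and compound 3 do not mean that the group on sulfur is unimportant. With the 4-methylphenyl group in place on both compounds, 3,5-dimethylphenyl in place of 2-methoxyphenyl on a double-bonded chain carbon bound to a double-bonded chain carbon gives no change at the digits printed from compound 2 to compound 4 (within the scatter) and so this exchange, unlike the two above, moves nothing beyond the scatter.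

On these data alone, it remains open whether an unsubstituted phenyl, a 4-methoxyphenyl or an amine on the sulfonyl sulfur would fall with the lower pair of numbers or the higher pair. Nothing available here gives a measured reason why the 4-methylphenyl and 4-methylbenzyl compounds differ.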